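The source may report more compounds than this note shows. Statements on the series, on what has been measured and on what is new or still open speak of the compounds shown alone.

Two compounds have been measured in a functional assay on K562 cells (Homo sapiens) for cytotoxicity, with a stated time of 72 h; a lower number here means a stronger inhibitor, a higher number a weaker inhibitor:

compound 1 `C[C@@H](NC(=O)c1cc(Cl)ccc1O)C(=O)Nc1ccc(Cl)cc1`, > 20000 nM
compound 2 `CC(C)[C@H](NC(=O)c1ccc(Cl)cc1O)C(=O)Nc1ccc(Br)cc1`, > 10000 nM

Both of these values are limits of this assay rather than numbers. For compound 1 the value > 20000 nM is the limit noted as the limit of > 20000 nM in this assay, at which 1 of the 2 values shown sits. For compound 2 the value > 10000 nM is the limit noted as the limit of > 10000 nM in this assay, at which 1 of the 2 values shown sits. Going by the values given here, compound 2 thus stands at a limit: this assay gives no number for it, and the one other value shown is a limit as well, so no step between measured compounds can be counted.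

Compound 3 `CC(C)[C@H](NC(=O)c1ccc(Cl)cc1O)C(=O)Nc1ccc(Cl)c(Cl)c1` differs from compound 2 in one place: 3,4-dichlorophenyl in place of 4-bromophenyl on an amide-type nitrogen. Among the compounds with values here, neither measured compound has a number in this assay, and no step can be drawn from the data. The expectation for compound 3 is therefore no step beyond the usual scatter, which means a result that again sits at or past the limit of this assay. Compound 3 is estimated at 15000 nM, within the range 3000 nM to 60000 nM. The step that this estimate means is expected to be a step that the limit leaves unreadable from compound 2 to compound 3.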

Compound 3, half-maximal inhibitory concentration: > 10000 nM
Compound 3: no number, only a limit; the forecaster's own chance of this, stated with the estimate: 75%; the middle value lies beyond the limit too.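

In this assay compound 3 gives > 10000 nM, which is a limit and not a number. Compound 2 also stands at a limit, so no new step can be read between compound 2 and compound 3. The compounds shown leave open how strong any of them is in this assay, and whether 3,4-dichlorophenyl and 4-bromophenyl differ there at all.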